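Benzyl for pyridinyl on the pyrazole nitrogen of compound 1

The source may report more compounds than this note shows. Statements on the series, on what has been measured and on what is new or still open speak of the compounds shown alone.

Three compounds of this series have numbers in an assay on isolated protein for inhibition of Myeloperoxidase (Homo sapiens), with a stated time of 10 min; on this read-out lower numbers stand for stronger inhibition and higher numbers for weaker inhibition. Compound 1 `Nc1cc(Cc2ccn(-c3ccccn3)n2)c2nn[nH]c2n1` gives 54 nM; compound 2 `Nc1cc(Cc2ccn(Cc3ccc4cnccc4c3)n2)c2nn[nH]c2n1` gives 140 nM; compound 3 `Nc1cc(C2CCNC3CCC(CC3)COc3cccc(c3)Cn3cc2cn3)c2nn[nH]c2n1` gives 31 nM. On these numbers compound 1 stands second highest: its number and that of compound 3 lie within the scatter of each other, while compound 2 shows a higher number, beyond the scatter. Going by the values given here, no single-point step between measured compounds is available, so no measured step size can be drawn on.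

Compound 4 `Nc1cc(Cc2ccn(Cc3ccccc3)n2)c2nn[nH]c2n1` differs from compound 1 in one place: benzyl in place of pyridin-2-yl on an aromatic nitrogen. The group entering is of the kind carried by compound 2, which shows a higher number than compound 1, and the structural change is modest in size.

The step of a 2.0-fold higher number from compound 1 to compound 4 (0.31 log units; beyond the scatter) is expected to be a moderate rise in number, toward weaker inhibition, resting on the higher number of compound 2 140 nM. Compound 4 is estimated at 110 nM, with a range from 40 nM to 300 nM.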

Compound 4, half-maximal inhibitory concentration: 120 nM
For compound 4 the middle estimate is 1.1-fold (0.04 log units) below the measured one, within the range that was stated.
By their numbers in this assay, from the lowest: compounds 3 and 1 (each within the scatter of the next); then compounds 4 and 2 (each within the scatter of the next).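

In this assay, going by these compounds alone, this is the first single-place step: benzyl in place of pyridin-2-yl on an aromatic nitrogen gives a 2.2-fold higher number from compound 1 to compound 4 (0.35 log units; beyond the scatter), so the number at this position depends on the group carried there. The step combines two changes, the loss of the hydrogen-bond acceptor counted for pyridin-2-yl and a move from 6 to 7 heavy atoms, and it cannot be divided between them. Nothing on hand bears on why the number rises.

Phenyl and pyridin-2-ylmethyl on the same nitrogen would separate the ring nitrogen from the added methylene link, and the compounds shown include neither. Also open, going by these compounds, is how a benzyl ring carrying an amine or a carboxylic acid would read in this assay.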